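This account rests on a few compounds, and the source may have more. Where it says the series, first, only, none or still open, it means among the compounds named here.

Compound 1 `CCCC(Oc1ccc(-n2cc(OC)cn2)cc1)c1ccc(C(=O)NCCC(=O)O)cc1` gives 4400 nM
Compound 2 `CCCC(Oc1ccc(-n2cc3c(n2)CCCC3)cc1)c1ccc(C(=O)NCCC(=O)O)cc1` gives 690 nM

Both numbers come from an assay on cells for displacement of a labelled ligand from Glucagon receptor (Homo sapiens), in the presence of a further agent that is not named here; a higher number here means a weaker inhibitor, a lower number a stronger inhibitor. Among the compounds with values here, compound 2 gives the lowest of the two numbers measured; the only step so far is a 6.4-fold lower number from compound 1 to compound 2 (0.80 log units; beyond the scatter), which shows that the group on that aromatic carbon can shift the result well beyond the scatter. Compound 3 `CCCC(Oc1ccc(-n2cccn2)cc1)c1ccc(C(=O)NCCC(=O)O)cc1` carries a group of 5 heavy atoms (3 carbon, 2 nitrogen; one five-membered aromatic ring with 2 hetero atoms) in place of a group of 9 heavy atoms (7 carbon, 2 nitrogen; one five-membered aromatic ring with 2 hetero atoms, one six-membered non-aromatic ring of carbon only), on an aromatic carbon. Within the data shown here, no measured step covers this exact change, so the direction rests only on that one step. Compound 3 is expected to give about 2500 nM (range 800 nM to 8000 nM). That estimate means an expected 3.6-fold higher number from compound 2 to compound 3 (0.56 log units; beyond the scatter), a weaker inhibitor than compound 2.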

Compound 3, inhibition constant: 4100 nM
Compound 3: middle estimate off by 1.6-fold (0.21 log units), on the low side; the range from low to high includes it.
By their numbers in this assay, from the lowest: compound 2; then compounds 3 and 1 (each within the scatter of the next).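

Hydrogen in place of methoxy gives a 1.1-fold lower number from compound 1 to compound 3 (0.03 log units; within the scatter), so this methoxy group makes no readable difference. Compound 2 alone stands apart: the plain 1H-pyrazol-1-yl group in place of its larger two-ring group gives a 5.9-fold higher number from compound 2 to compound 3 (0.77 log units; beyond the scatter), so the gain seen earlier belongs to the added six-membered non-aromatic ring of carbon. No measurement here explains this difference.

As far as these compounds go, how much of that ring is needed remains open. A 1H-pyrazol-1-yl group carrying methyl or ethyl, or bearing a five-membered carbon ring instead, could show this.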